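Exchanging 3-methoxyphenyl for 3,4-dichlorophenyl: notes on the series

The compounds below may be only part of what the source reports. "The series", "measured", "known", "first", "only" and "open" are said of these compounds alone.

compound 1 `COc1cccc(N2CCN(c3c(CO)c(=O)oc4ccccc34)CC2)c1` reads 6510 nM here
compound 2 `O=c1oc2ccccc2c(N2CCN(C(c3ccc(F)cc3)c3ccc(F)cc3)CC2)c1CO` reads 3160 nM here

In a functional assay on A-375 cells (Homo sapiens) for inhibition, read by MTT assay, with a stated time of 24 h (on this read-out higher numbers stand for weaker inhibition and lower numbers for stronger inhibition), compound 1 has the higher of the two numbers, which makes it the weaker inhibitor of the pair. Compound 2 lies lower by a margin just beyond the scatter. Within the data shown here, no measured pair differs in one place only, so the data offer no direct guide to the next change.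

Compound 3 `O=c1oc2ccccc2c(N2CCN(c3ccc(Cl)c(Cl)c3)CC2)c1CO` has 3,4-dichlorophenyl in place of 3-methoxyphenyl on an amine nitrogen in a ring, and the difference 3,4-dichlorophenyl in place of 3-methoxyphenyl on an amine nitrogen in a ring leaves the rest of compound 1 unchanged. Very different groups at that nitrogen still give nearby numbers, with compound 1 at 6510 nM and compound 2 at 3160 nM in this assay as the only evidence. A small downward move is therefore expected, and a 1.6-fold lower number from compound 1 to compound 3 (0.21 log units; within the scatter) is the estimated step, within the scatter. The estimate for compound 3 is 4000 nM with a range from 1500 nM to 10000 nM around it.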

Compound 3, half-maximal inhibitory concentration: 7660 nM
The estimate for compound 3 lay 1.9-fold (0.28 log units) below the measured number, and the stated range covers the measured number.
By their numbers in this assay, from the lowest: compound 2; then compounds 1 and 3 (each within the scatter of the next).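

In this assay, among these compounds, the exchange on the amine nitrogen in the ring gives a 1.2-fold higher number from compound 1 to compound 3 (0.07 log units; within the scatter) and so provides the first direct reading at this position. The group that leaves carries a hydrogen-bond acceptor and the group that enters carries none, yet compound 1 and compound 3 stay within the scatter of each other, so this exchange of one substituted phenyl group for another does not separate the two compounds here. No measurement at hand bears on why the two groups read alike.

Still open, as far as these compounds go, is how an unsubstituted pyridine ring would read on that same nitrogen in place of either phenyl group. The compounds shown also leave open any change elsewhere on the shared core, such as a carboxylic acid in place of the hydroxymethyl group.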